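The source may report more compounds than this note shows. Statements on the series, on what has been measured and on what is new or still open speak of the compounds shown alone.

Compound 3 `COc1ccc(C(=O)Nc2ncc(Cc3cccc(C(F)(F)F)c3)s2)cc1OCCCO` carries a 3-hydroxypropoxy chain on its benzamide ring and a trifluoromethyl-substituted benzyl group on the shared core. In an assay on microsomes for inhibition of acyl-CoA desaturase 1 (Mus musculus), with a stated time of 60 min (a higher number here means a weaker inhibitor, a lower number a stronger inhibitor), compound 3 is recorded as "not determined" (no result reported), so no number stands for it. The two neighbours that do have results frame the series. Compound 1 `O=C(Nc1ncc(Cc2cccc(C(F)(F)F)c2)s1)c1ccc2ccccc2c1` gives > 10000 nM in this assay, which is a limit of the assay and not a number, in line with the limit of > 10000 nM in this assay, at which 1 of the 3 values shown sits. Compound 2 `COc1ccc(C(=O)Nc2ncc(Cc3cc(Cl)cc(Cl)c3)s2)cc1OCCO`, with a 2-hydroxyethoxy chain and a dichlorobenzyl group, gives 0.7 nM in this assay. Within the data shown here, no step between measured compounds is available, so the effect of the chain itself cannot be read from a pair. Compound 4 `COc1ccc(C(=O)Nc2ncc(Cc3cccc(C(F)(F)F)c3)s2)cc1OCC(=O)O` differs from compound 3 by carboxy in place of 2-hydroxyethyl on a saturated chain carbon bound to an oxygen on an aromatic ring. Exchanging the hydroxyl-terminated chain for a carboxymethoxy group is expected to cost potency in this assay by a step beyond the usual scatter, rather than to leave it unchanged or improve it. With compound 2 at 0.7 nM as the only potent anchor, compound 4 is expected to reach about 60 nM, with a plausible range from 3 nM to 1500 nM.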

Compound 4, half-maximal inhibitory concentration: > 9990 nM
Compound 4 gave a limit, no number (the forecaster's own chance of this, stated with the estimate: 20%); at least 160-fold (2.22 log units) between middle value and limit.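

No step can be read between compound 3 and compound 4, since compound 3 has no reported result in this assay. Compound 4 gives > 9990 nM, which is a limit of the assay and not a number. The compounds shown leave open how the 3-hydroxypropoxy chain itself bears on inhibition in this assay.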